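This account rests on a few compounds, and the source may have more. Where it says the series, first, only, none or still open, it means among the compounds named here.

Of the compounds shown here, three sharing one core have been measured in a physicochemical assay for solubility, read by HPLC, in phosphate buffer, at pH 7.4; a lower number here means a less soluble compound, a higher number a more soluble compound. Within the data shown here, compound 1 `COc1ccc(-c2ccnc(Nc3ccc(C(=O)O)cc3)n2)cc1` gives 12100 nM, the only true number of the three. Compound 2 `COc1ccc(-c2ccnc(Nc3ccc(C(N)=O)cc3)n2)cc1` gives < 600 nM, which is a limit of the assay and not a number. Compound 3 `COc1ccc(-c2ccnc(Nc3cccc(NS(C)(=O)=O)c3)n2)cc1` gives < 500 nM, which is also a limit. Among the measured compounds shown here, compound 2 therefore has no number of its own, and the one further value shown beside it is a limit too.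

The next step leads to compound 4 `COC(=O)c1ccc(Nc2nccc(-c3ccc(OC)cc3)n2)cc1`, which has not yet been measured in this assay. The change is methoxy in place of amino on a carbonyl carbon. For the measured compounds named here, the one measured step at this carbonyl carbon is an at least 20-fold lower number from compound 1 to compound 2 (1.30 log units; beyond the scatter), a large one, with amino in place of hydroxy. Compound 4 does not bring the hydroxy back, so that step gives no ground to expect a return towards compound 1 at 12100 nM. Going by the values given here, no measured step shows what methoxy does at this place, so the expectation is cautious and no change beyond the scatter is foreseen. The expected step is a step that the limit leaves unreadable from compound 2 to compound 4. For compound 4 the estimated value is 350 nM, with an expected range from 80 nM to 1500 nM.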

Compound 4, solubility: 6900 nM
Compound 4: middle estimate off by 20-fold (1.29 log units), on the low side; measured number above the stated range.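

In this assay, the earlier fall at this carbonyl carbon now proves not to be tied to the loss of hydroxy alone, as methoxy in place of amino gives an at least 11-fold higher number from compound 2 to compound 4 (1.06 log units; beyond the scatter). Placing a methyl on the oxygen next to a carbonyl group gives a 1.8-fold lower number from compound 1 to compound 4 (0.24 log units; within the scatter), so these two compounds stand level within the scatter, and of the three groups shown on this carbonyl carbon only amino goes with a reading that is a limit. The reading of compound 2 is a limit and not a number, so the true size of the steps to and from it stays unknown: the limit of < 600 nM in this assay, at which 1 of the 4 values shown sits.

The compounds shown leave open whether the high reading needs an oxygen attached to this carbonyl carbon or only the absence of amino, a question that methylamino or a longer chain such as ethoxy at the same place would help to separate. They also give no cause for the gap between amino and methoxy, which here remains a measured difference without an explanation.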